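Carboxylic acid and benzylamine on the shared core

The source may hold more compounds than are shown below. What is called first, only, known or untested is meant among the compounds shown, and "the series" means these compounds.

Compound 1, `CNC(=O)c1cnc(NC(=O)NC2CCCCC2)n2nc(-c3ccco3)nc12`: > 30000 nM in a functional assay on CHO cells for antagonist activity at adenosine receptor A2b (Homo sapiens); a higher number here means a weaker inhibitor, a lower number a stronger inhibitor (a limit of the assay)
Compound 2, `O=C(Nc1ncc(C(=O)O)c2nc(-c3ccco3)nn12)NC1CCCCC1`: > 30000 nM in this assay (a limit of the assay)
Compound 3, `CCOC(=O)c1cnc(NCC2CCCCC2)n2nc(-c3ccco3)nc12`: > 10000 nM in this assay (a limit of the assay)

Among the measured compounds shown here, compound 2 stands only at a limit in this assay, and the two further values shown are likewise limits, so no compound here has a number of its own. For the measured compounds named here, the single step between measured compounds, a step that the two limits leave unreadable from compound 1 to compound 2, cannot be read because both ends are limits.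

Compound 4, `O=C(O)c1cnc(NCc2ccc(F)cc2)n2nc(-c3ccco3)nc12`, differs from compound 2 in one place: 4-fluorobenzyl in place of cyclohexylcarbamoyl on a nitrogen on an aromatic ring. Going by the values given here, no measured step bears directly on this change. Among the compounds with values here, what the data offer is that compound 2 keeps its carboxylic acid and sits at the limit of > 30000 nM in this assay, at which 2 of the 3 values shown sit, while compound 3, the only one with an alkylamino group in place of the urea, sits at the limit of > 10000 nM in this assay, at which 1 of the 3 values shown sits. Both neighbours of compound 4 thus lie at limits, and nothing points to a measurable inhibitor; the expectation for a number no higher from compound 2 to compound 4 (the limit leaves the size open) is therefore no readable step, with a result again most likely reported as a limit.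

The estimate for compound 4 in this assay is 30000 nM, expected to fall between 5000 nM and 100000 nM.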

Compound 4, inhibition constant: > 30000 nM
Compound 4: a limit, no number (the forecaster's own chance of this, stated with the estimate: 75%); the middle value lies on the limit itself.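

Compound 4 gives > 30000 nM in this assay, a limit of the assay and not a number. Compound 2 also stands at a limit, so no step can be read between compound 2 and compound 4. The compounds shown leave open how strongly any of them inhibits, and whether exchanging cyclohexylcarbamoyl for 4-fluorobenzyl changes anything on the shared core.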